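The source may hold more compounds than are shown below. What is called first, only, known or untested is meant among the compounds shown, and "the series" means these compounds.

Compound 1 `CSc1nc(Cl)c(C(=O)c2ccccc2)s1` and compound 2 `CSc1nc(Br)c(C(=O)c2ccccc2)s1` share one core and differ in a single place: bromo in place of chloro on an aromatic carbon. In a functional assay on PC-3 cells (Homo sapiens) for cytotoxicity, read by MTT assay, with a stated time of 72 h (on this read-out lower numbers stand for stronger inhibition and higher numbers for weaker inhibition), compound 1 gives only the limit of the assay, > 100000 nM, and no number. Compound 2 likewise gives only a limit, > 100000 nM. The step that the two limits leave unreadable from compound 1 to compound 2 therefore cannot be sized, as the limit of > 100000 nM in this assay, at which 2 of the 2 values shown sit, shows. So compound 2 stands at a limit, not at a measured value.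

Compound 3 `O=C(c1ccccc1)c1sc(N2CCCCC2)nc1Br` differs from compound 2 by piperidin-1-yl in place of methylsulfanyl on an aromatic carbon. Among the measured compounds shown here, no measured step touches this change; the one step measured, chloro to bromo, stays unreadable, so nothing shows whether replacing methylsulfanyl with piperidin-1-yl moves the read-out. With both measured compounds at the limit, compound 3 is expected to give about 100000 nM, most likely again only a limit, in a range from 15000 nM to 300000 nM. The expected step of a number no higher from compound 2 to compound 3 (the limit leaves the size open) is thus no change beyond the scatter.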

Compound 3, half-maximal inhibitory concentration: 62000 nM
Beside the measured number, compound 3's estimate is 1.6-fold (0.21 log units) above it; the measured number falls inside the stated range.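

Placing piperidin-1-yl on the aromatic carbon next to the ring nitrogen and next to the ring sulfur gives the first true number on this core in this assay, something the chloro to bromo step, which cannot be read, did not provide. The change from methylsulfanyl is an at least 1.6-fold lower number from compound 2 to compound 3 (0.20 log units; that floor lies within the scatter), so the printed floor alone does not separate the two compounds, although the real step may be larger. Its full size stays unknown, since the comparison rests on a limit rather than on two numbers: the limit of > 100000 nM in this assay, at which 2 of the 3 values shown sit.

The compounds shown leave open whether another amine at this place, such as morpholin-4-yl or open-chain dimethylamino, would give a lower number. They also leave open whether chloro in place of bromo would change the reading once piperidin-1-yl is present.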